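From ethoxy to 2-hydroxyethyl at the assay limit

This account rests on a few compounds, and the source may have more. Where it says the series, first, only, none or still open, it means among the compounds named here.

Compound 1 `CCOc1ccc2c(c1)NC(=O)Nc1cnc(C#N)c(n1)OCCCCCO2`: > 10000 nM
Compound 2 `N#Cc1ncc2nc1OCC/C=C\COc1ccc(CCO)cc1NC(=O)N2`: > 10000 nM

In a functional assay on NCI-H1299 cells (Homo sapiens), read by flow cytometry (on this read-out higher numbers stand for an effect only at larger amounts of compound and lower numbers for an effect already at smaller amounts), compound 1 gives > 10000 nM, which is a limit and not a number. Compound 2 gives > 10000 nM, which is also a limit. The record so far is therefore (the limit of > 10000 nM in this assay, at which 2 of the 2 values shown sit), and it offers no number from which to rank the two.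

Compound 3 `N#Cc1ncc2nc1OCCCCCOc1ccc(CCO)cc1NC(=O)N2` has the same atoms as compound 1, joined differently, with 2-hydroxyethyl in place of ethoxy on an aromatic carbon. Within the data shown here, no measured step shows what such a swap does in this assay. With compound 1 at the limit of > 10000 nM, no large gain is expected from this change. The estimated a number no higher from compound 1 to compound 3 (the limit leaves the size open) is expected to stay within the usual scatter, with neither direction favoured. Compound 3 is expected at 10000 nM, with an estimated range of 3000 nM to 30000 nM.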

Compound 3, half-maximal effective concentration: > 10000 nM
Compound 3 ended at the assay's limit (the forecaster's own chance of this, stated with the estimate: 65%); the middle value sits exactly at the limit.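

The swap of ethoxy for 2-hydroxyethyl gives no readable step between compound 1 and compound 3, because both values are limits and not numbers: the limit of > 10000 nM in this assay, at which 3 of the 3 values shown sit.

In this assay the compounds shown leave open what number any of them would give, and so what this swap does.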